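The source may hold more compounds than are shown below. What is called first, only, known or untested is meant among the compounds shown, and "the series" means these compounds.

Measured compounds:
compound 1 `COc1cc(F)c(CN2C(=O)N(c3cc(OC)nc(OC)c3)S(=O)(=O)c3ccccc32)c(F)c1` — 0.251 nM
compound 2 `COc1cc(F)c(CN2C(=O)N(c3ccc(OC)c(OC)c3)S(=O)(=O)c3ccccc32)c(F)c1` — 0.501 nM
compound 3 `COc1ccc(N2C(=O)N(Cc3ccccc3F)c3ccccc3S2(=O)=O)cc1OC` — 6.31 nM

All three were tested in an assay on HEK293 cells for displacement of a labelled ligand from Orexin receptor type 2 (Homo sapiens), read by scintillation counting, with a stated time of 90 min; a lower number here means a stronger inhibitor, a higher number a weaker inhibitor. Compound 2 stands second highest of the three numbers: compound 1 lies nearest, with a 2.0-fold higher number from compound 1 to compound 2 (0.30 log units; within the scatter) between them, while compound 3 lies furthest, with a 13-fold higher number from compound 2 to compound 3 (1.10 log units; beyond the scatter).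

The unmeasured compound 4 `COc1cc(F)c(CN2C(=O)N(c3cnc(OC)c(OC)c3)S(=O)(=O)c3ccccc32)c(F)c1` differs from compound 2 in one place: 5,6-dimethoxypyridin-3-yl in place of 3,4-dimethoxyphenyl on an amide-type nitrogen in a ring. The change thus sits on the same ring nitrogen as the change from compound 1 to compound 2, which exchanged a dimethoxypyridinyl group for a dimethoxyphenyl group and gave a 2.0-fold higher number from compound 1 to compound 2 (0.30 log units; within the scatter), a step within the scatter. For the measured compounds named here, that step is the one that bears on compound 4; the step from compound 2 to compound 3 concerns the benzyl group on the other ring nitrogen, a different place, and does not speak to this change. On this basis the return from a dimethoxyphenyl group to a dimethoxypyridinyl group, now with the nitrogen at a different ring position, is expected to give no step beyond the scatter in this assay, perhaps a slightly lower number, so that the expected step is a 1.3-fold lower number from compound 2 to compound 4 (0.10 log units; within the scatter). Compound 4 is therefore estimated at 0.4 nM, with a likely range from 0.15 nM to 1.2 nM.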

Compound 4, inhibition constant: 0.398 nM
The estimate for compound 4 lay 1.0-fold (0.00 log units) above the measured number, within the range that was stated.
By their numbers in this assay, from the lowest: compounds 1, 4 and 2 (each within the scatter of the next); then compound 3.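

In this assay, the exchange of 3,4-dimethoxyphenyl for 5,6-dimethoxypyridin-3-yl on this amide-type nitrogen in a ring stays within the scatter (a 1.3-fold lower number from compound 2 to compound 4 (0.10 log units; within the scatter)), although the entering group has a ring nitrogen in place of a ring carbon and one more hydrogen-bond acceptor by count. For the compounds shown here, the two dimethoxypyridinyl groups can now be compared directly, and moving from 2,6-dimethoxypyridin-4-yl to 5,6-dimethoxypyridin-3-yl also stays within the scatter (a 1.6-fold higher number from compound 1 to compound 4 (0.20 log units; within the scatter)), so the three groups at this position cannot be told apart in this measurement, whereas the earlier compounds offered only a single comparison here. Nothing available gives a reason why these exchanges leave the number within the scatter.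

On these data alone, all three groups at this position are six-membered aromatic rings with two methoxy groups, so it remains open whether a ring carrying an amine or a carboxylic acid instead, or a longer alkoxy chain in place of methoxy, would stay in the same range. As far as these compounds go, it is also open whether 5,6-dimethoxypyridin-3-yl would behave the same way alongside the 2-fluorophenyl group of compound 3.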